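Piperazinyl in place of bridged diamine: stability notes

The source may hold more compounds than are shown below. What is called first, only, known or untested is meant among the compounds shown, and "the series" means these compounds.

Working notes on the series. The shared core carries a cyclic diamine on an aromatic carbon and a tertiary amine side chain. Compound 1 `CCCN(C[C@H]1Cc2c(cccc2N2CCNCC2)CN1)[C@H]1CCCc2cccnc21` was run in an ADME assay on microsomes from liver (Homo sapiens) for metabolic stability, read by LC-MS, with a stated time of 10 min (on this read-out higher numbers stand for a more stable compound and lower numbers for a less stable compound), where compound 1 gives 100%. Compound 2 `Cc1cnc(CN(C)C[C@H]2Cc3c(cccc3N3CCNCC3)CN2)c(C)c1` belongs to the same set, and in this assay compound 2 gives "not determined" (no result reported), so no number is available for compound 2 there. Compound 3 `CN(C[C@H]1Cc2c(cccc2N2C[C@@H]3C[C@H]2CN3)CN1)[C@H]1CCCc2cccnc21` in this assay gives 100%, level with compound 1 at the digits shown, the two values lying within the usual scatter of each other. Going by the values given here, no single-change step between measured compounds is available, so these values are read side by side only.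

Compound 4 `CN(C[C@H]1Cc2c(cccc2N2CCNCC2)CN1)[C@H]1CCCc2cccnc21` has not been measured. Its difference from compound 3 is a group of 6 heavy atoms (4 carbon, 2 nitrogen; one six-membered non-aromatic ring with 2 hetero atoms) in place of a group of 7 heavy atoms (5 carbon, 2 nitrogen; 2 five-membered non-aromatic rings with 1 hetero atom each), on an aromatic carbon. The expected step of no change at the digits printed from compound 3 to compound 4 (within the scatter) is none beyond the scatter, in no particular direction. Given that compound 3 gives 100% in this assay, compound 4 is expected to give 100%, with an estimated range from 85% to 100%.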

Compound 4, percent of the compound remaining: 99.7%
Compound 4: middle estimate off by 0.3 percentage points, on the high side, and the stated range covers the measured number.
By their numbers in this assay, from the lowest: compounds 4, 1 and 3 (each within the scatter of the next).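

In this assay the series now has single-change comparisons. Piperazin-1-yl on the aromatic carbon, in place of the group of 7 heavy atoms with two five-membered non-aromatic rings, gives a number 0.3 percentage points lower from compound 3 to compound 4 (within the scatter) and so does not separate the two ring groups at this position. Hydrogen in place of ethyl on the saturated chain carbon bound to the amine nitrogen gives a number 0.3 percentage points lower from compound 1 to compound 4 (within the scatter) and so does not separate the two side chains either. No measurement at hand bears on a cause for these results. Still open, on these data alone, is whether a morpholine or a primary amine on the same aromatic carbon would remain within the scatter of compound 4 in this assay and whether a benzyl group on the side chain amine would do the same.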